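Removing One Chlorine from the Weakest Compound

A few compounds are considered here, and "the series" means these few. Any claim that something is new, unique, unknown or untested is made for them only; others in the source may bear on it.

In a functional assay on HCT-116 cells (Homo sapiens) for cytotoxicity, read by MTT assay, with a stated time of 72 h (on this read-out lower numbers stand for stronger inhibition and higher numbers for weaker inhibition), three compounds were tested. Compound 1 `Cc1cc(S(=O)(=O)/N=C(\N)n2nccc2-c2ccccc2)c(SCc2ccccc2Cl)cc1Cl` gives 18000 nM, compound 2 `Cc1cc(-c2ccccc2)n(/C(N)=N/S(=O)(=O)c2cc(C)c(Cl)cc2SCc2cccc3ccccc23)n1` gives 7000 nM, and compound 3 `Cc1cc(-c2ccccc2)n(/C(N)=N/S(=O)(=O)c2cc(C)c(Cl)cc2SCc2ccccc2Cl)n1` gives 170000 nM, the highest number of the three and therefore the weakest. Two measured steps lead to it: a 9.4-fold higher number from compound 1 to compound 3 (0.98 log units; beyond the scatter) and a 24-fold higher number from compound 2 to compound 3 (1.39 log units; beyond the scatter). Compound 4 `Cc1cc(-c2ccccc2)n(/C(N)=N/S(=O)(=O)c2cc(C)c(Cl)cc2SCc2ccccc2)n1` differs from compound 3 by hydrogen in place of chloro on an aromatic carbon. Among the compounds with values here, only the second of those steps touches the same benzylsulfanyl region, and it was large, so that region clearly matters; no measured step, however, shows a chloro replaced by hydrogen, so the direction cannot be read from the data. Only a modest step is therefore expected, a 1.4-fold lower number from compound 3 to compound 4 (0.15 log units; within the scatter). Compound 4 is estimated at 120000 nM, with a range of 40000 nM to 400000 nM.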

Compound 4, half-maximal inhibitory concentration: 10000 nM
Estimate against measurement, compound 4: 12-fold (1.08 log units) above; measured number below the stated range.
By their numbers in this assay, from the lowest: compounds 2, 4 and 1 (each within the scatter of the next, the first and the last beyond it); then compound 3.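

In this assay, going from 2-chlorobenzyl to benzyl gives a 17-fold lower number from compound 3 to compound 4 (1.23 log units; beyond the scatter), so one chlorine atom on an aromatic carbon is enough to produce a large change in this series. Phenyl and naphthalen-1-yl at this end of the chain cannot be told apart, since a 1.4-fold higher number from compound 2 to compound 4 (0.15 log units; within the scatter) stays within the scatter. Nothing measured here explains the effect of the chloro group. Whether the large change is specific to chlorine stays open, as the compounds shown include no fluoro, methyl or methoxy group at that aromatic carbon. Also open, as far as these compounds go, is whether the same change would have a similar effect in compound 1.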